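The source may report more compounds than this note shows. Statements on the series, on what has been measured and on what is new or still open speak of the compounds shown alone.

Among the measured compounds shown here, compound 2 `CC(=O)OC/C(=C\c1ccc(F)cc1)C(=O)c1ccccc1` gives 13000 nM in a functional assay on WiDr cells (Homo sapiens) for inhibition, read by sulforhodamine B assay, with a stated time of 48 h (a higher number here means a weaker inhibitor of growth, a lower number a stronger inhibitor of growth), the lower of the two numbers measured so far; its only neighbour, compound 1 `CCC(/C=C(\COC(C)=O)C(=O)c1ccccc1)CC`, gives 52000 nM in this assay, and a 4.0-fold lower number from compound 1 to compound 2 (0.60 log units; beyond the scatter). Compound 3 `CC(=O)OC/C(=C\c1ccccc1Br)C(=O)c1ccccc1` differs from compound 2 by 2-bromophenyl in place of 4-fluorophenyl on a double-bonded chain carbon bound to a double-bonded chain carbon. For the measured compounds named here, the one measured step swapped a chain for an aromatic ring, not one aromatic ring for another, so it offers no guide here, and no step beyond the scatter is expected. Compound 3 is therefore estimated at 13000 nM, within 5000 nM to 35000 nM. That estimate means an expected no change at the digits printed from compound 2 to compound 3 (within the scatter).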

Compound 3, concentration for 50% growth inhibition: 21000 nM
The estimate for compound 3 lay 1.6-fold (0.21 log units) below the measured number; the range from low to high includes it.
By their numbers in this assay, from the lowest: compounds 2 and 3 (each within the scatter of the next); then compound 1.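

In this assay, the step of a 1.6-fold higher number from compound 2 to compound 3 (0.21 log units; within the scatter) shows that one halogen-bearing aromatic ring can replace another at this place without a clear shift. The step of a 2.5-fold lower number from compound 1 to compound 3 (0.39 log units; beyond the scatter) shows that the lower number relative to pentan-3-yl is not unique to 4-fluorophenyl. Nothing available explains either step.

The step from 4-fluorophenyl to 2-bromophenyl changes both the halogen and its ring position, so 2-fluorophenyl or 4-bromophenyl would be needed to separate them. On these data alone, how a ring bearing an amine or a carboxylic acid would read remains open.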